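The compounds below may be only part of what the source reports. "The series", "measured", "known", "first", "only" and "open" are said of these compounds alone.

Compound 1 `Cc1cc(O)c(C(=O)/C=C/c2ccc(Cl)cc2)c(-c2ccc(OCc3ccccc3)cc2)c1C(=O)/C=C/c1ccc(Cl)cc1` was tested in a functional assay on MDA-MB-231 cells (Homo sapiens) for cytotoxicity, read by MTT assay, with a stated time of 24 h (on this read-out lower numbers stand for stronger inhibition and higher numbers for weaker inhibition), where compound 1 gives 30000 nM. Two further compounds share much of its build. Compound 2 `Cc1cc(O)c(C(=O)/C=C/c2ccc(OCc3ccccc3)cc2)c(-c2ccc(Br)cc2)c1C(=O)/C=C/c1ccc(OCc2ccccc2)cc1` gives 20000 nM in this assay, and compound 3 `Cc1cc(O)c(C(=O)/C=C/c2ccc(OCc3ccccc3)cc2)c(-c2ccc(OCc3ccccc3)cc2)c1C(=O)/C=C/c1ccc(OCc2ccccc2)cc1` gives 20000 nM in this assay. Compound 3 turns into compound 2 through one change, (bromo in place of benzyloxy on an aromatic carbon), and that step, no change at the digits printed from compound 3 to compound 2 (within the scatter), leaves the number essentially where it was. The difference between the core of compound 1 and that of compound 3 is not broken down here. Compound 4 `Cc1cc(O)c(C(=O)/C=C/c2ccc(Cl)cc2)c(-c2ccc(Br)cc2)c1C(=O)/C=C/c1ccc(Cl)cc1` is not yet measured; it arises from compound 1 by the same change, (bromo in place of benzyloxy on an aromatic carbon). The step from compound 1 to compound 4 is expected to be no change at the digits printed from compound 1 to compound 4 (within the scatter), because the earlier step of no change at the digits printed from compound 3 to compound 2 (within the scatter) showed no shift. Compound 4 is therefore estimated at 30000 nM, between 15000 nM and 60000 nM.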

Compound 4, half-maximal inhibitory concentration: 15000 nM
The estimate for compound 4 lay 2.0-fold (0.30 log units) above the measured number; the measured number falls inside the stated range.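

In this assay, putting bromo in place of benzyloxy on the aromatic carbon gives a 2.0-fold lower number from compound 1 to compound 4 (0.30 log units; within the scatter). Set beside the earlier case, the change behaves alike on both cores: the same change on two cores in this assay, no change at the digits printed (within the scatter) from compound 3 to compound 2 and a 2.0-fold lower number (0.30 log units; within the scatter) from compound 1 to compound 4, 2.0-fold (0.30 log units) apart, within the scatter of two such steps. This shows that, in these two pairs, the change carries from one core to the other without a shift that stands out from the scatter, but two pairs cannot show that it would do so on other cores in the series.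

The compounds shown leave open what an amine, a carboxylic acid or a longer chain would do in that place. They also leave open whether any group there can move the number beyond the scatter.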